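Notes on the step from compound 2 to compound 4

The source may report more compounds than this note shows. Statements on the series, on what has been measured and on what is new or still open speak of the compounds shown alone.

In a functional assay on HeLa cells (Homo sapiens) for cytotoxicity, read by MTT assay, with a stated time of 72 h (on this read-out higher numbers stand for weaker inhibition and lower numbers for stronger inhibition), compound 2 `COc1ccc(C(=O)c2cc(OC)c(OC)c(OC)c2)cc1NC(=O)/C=C/c1ccc(OC)c(OC)c1` gives 7800 nM, the highest number of the three measured, with compound 1 `COc1ccc(C(=O)c2cc(OC)c(OC)c(OC)c2)cc1NC(=O)/C=C/c1cc(OC)c(OC)c(OC)c1` at 1500 nM and compound 3 `COc1ccc(C(=O)c2cc(OC)c(OC)c(OC)c2)cc1NC(=O)/C=C/c1ccc(C(F)(F)F)cc1` at 90 nM. Compound 4 `COc1ccc(C(=O)c2cc(OC)c(OC)c(OC)c2)cc1NC(=O)/C=C/c1cccc(OC(F)(F)F)c1` differs from compound 2 by 3-(trifluoromethoxy)phenyl in place of 3,4-dimethoxyphenyl on a double-bonded chain carbon bound to a double-bonded chain carbon. Among the measured compounds shown here, two measured steps bear on this change, an 87-fold lower number from compound 2 to compound 3 (1.94 log units; beyond the scatter) and a 17-fold lower number from compound 1 to compound 3 (1.22 log units; beyond the scatter), both with 4-(trifluoromethyl)phenyl entering, while a 5.2-fold higher number from compound 1 to compound 2 (0.72 log units; beyond the scatter) is modest by comparison. For the measured compounds named here, no measured step places 3-(trifluoromethoxy)phenyl on that chain carbon, so the size is less sure than for compound 3. A large step down in this assay is therefore expected, a 20-fold lower number from compound 2 to compound 4 (1.29 log units; beyond the scatter). Compound 4 is estimated at 400 nM, within 100 nM to 2000 nM.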

Compound 4, half-maximal inhibitory concentration: 7900 nM
Estimate against measurement, compound 4: 20-fold (1.30 log units) below; measured number above the stated range.
By their numbers in this assay, from the lowest: compound 3; then compound 1; then compounds 2 and 4 (each within the scatter of the next).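

In this assay, fluorine in the entering group does not by itself bring a lower number at this chain carbon: a 1.0-fold higher number from compound 2 to compound 4 (0.01 log units; within the scatter) shows no separation between 3-(trifluoromethoxy)phenyl and 3,4-dimethoxyphenyl, whereas an 88-fold higher number from compound 3 to compound 4 (1.94 log units; beyond the scatter) sets it far from 4-(trifluoromethyl)phenyl. It also stands apart from the trimethoxy compound, with a 5.3-fold higher number from compound 1 to compound 4 (0.72 log units; beyond the scatter). No measurement here accounts for the difference between the two fluorinated groups. Open, as far as these compounds go, is whether the low number of compound 3 depends on the trifluoromethyl group itself or would also hold for a phenyl bearing a nitrile or a carboxylic acid.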